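Compound 3 to compound 4: propyl for 4-fluorophenyl

The source may hold more compounds than are shown below. What is called first, only, known or untested is meant among the compounds shown, and "the series" means these compounds.

compound 1 `O=C(CSc1ncc[nH]1)Nc1ccc2nc(NC(=O)c3ccc(C(F)(F)F)cc3)sc2c1`: 18800 nM
compound 2 `O=C(CSc1cccc(O)c1)Nc1ccc2nc(NC(=O)c3ccc(F)cc3)sc2c1`: 5120 nM
compound 3 `O=C(CSc1ccc(Cl)cc1)Nc1ccc2nc(NC(=O)c3ccc(F)cc3)sc2c1`: 2510 nM

In a functional assay on U2OS cells (Homo sapiens) for antiproliferative activity, read by MTT assay, with a stated time of 72 h (on this read-out lower numbers stand for stronger inhibition and higher numbers for weaker inhibition), compound 3 at 2510 nM holds the lowest of the three numbers. Compound 4 `CCCC(=O)Nc1nc2ccc(NC(=O)CSc3ccc(Cl)cc3)cc2s1` is not yet measured. It differs from compound 3 in one place, with propyl in place of 4-fluorophenyl on a carbonyl carbon, counted as propyl in place of 4-fluorophenyl on a carbonyl carbon in full. Within the data shown here, the one measured step, a 2.0-fold lower number from compound 2 to compound 3 (0.31 log units; beyond the scatter) for 4-chlorophenyl in place of 3-hydroxyphenyl on a sulfur, is modest and lies at a different place in the structure. Compound 1 at 18800 nM differs from compound 3 in two places and cannot isolate this change. Among the measured compounds shown here, no measured step therefore tests the 4-fluorophenyl directly, and the expectation is loose. In this assay the expected change is a 2.0-fold higher number from compound 3 to compound 4 (0.30 log units; within the scatter) toward a higher number, though a step in the other direction is not excluded. Compound 4 is estimated at 5000 nM with 1500 nM to 16000 nM as the expected range.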

Compound 4, half-maximal inhibitory concentration: 3190 nM
For compound 4 the middle estimate is 1.6-fold (0.20 log units) above the measured one; the measured number falls inside the stated range.
By their numbers in this assay, from the lowest: compounds 3, 4 and 2 (each within the scatter of the next, the first and the last beyond it); then compound 1.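

In this assay propyl in place of 4-fluorophenyl on a carbonyl carbon gives a 1.3-fold higher number from compound 3 to compound 4 (0.10 log units; within the scatter) and provides the first measured test of this position. Between compound 3 and compound 4, the one six-membered aromatic ring of carbon only and its fluorine are therefore not needed to hold the number at this level, since a propyl with 3 heavy atoms and no ring stands in for a group of 7 heavy atoms. No measured evidence accounts for this result.

Going by these compounds, whether the same holds for a longer chain, a cyclohexyl or a chain ending in an amine or a carboxylic acid remains open. The change has been read only with 4-chlorophenyl on the sulfur, so its outcome with 3-hydroxyphenyl or another group there is also unknown.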